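The compounds below may be only part of what the source reports. "The series", "measured", "known", "first", "only" and "open" are said of these compounds alone.

In an ADME assay on J774.A1 cells (Mus musculus) for cytotoxicity, read by MTT assay, with a stated time of 48 h; on this read-out lower numbers stand for higher toxicity in this test and higher numbers for lower toxicity in this test:
Compound 1 `O=C(NCc1cccc(Br)c1)c1c([N+](=O)[O-])noc1-c1ccc([N+](=O)[O-])cc1` - "not determined" (no result reported)
Compound 2 `COc1cccc(CNC(=O)c2c([N+](=O)[O-])noc2-c2ccc([N+](=O)[O-])cc2)c1` - "not determined" (no result reported)
Compound 3 `CCCNC(=O)c1c([N+](=O)[O-])noc1-c1ccc([N+](=O)[O-])cc1` - 76200 nM

Compound 2 has no single number to stand on, and neither has compound 1. Only compound 3 gives a number, so compound 2 cannot be ranked against it. Still unmeasured is compound 4 `COc1cccc(CNC(=O)c2c([N+](=O)[O-])noc2-c2ccc(Cl)cc2)c1`. Among the compounds with values here, the single structural change (chloro in place of nitro on an aromatic carbon) puts chloro in place of nitro on an aromatic carbon, taking 4-nitrophenyl to 4-chlorophenyl. Within the data shown here, no measured step exists to guide this, so in this assay no shift beyond the usual scatter is expected, and no direction is favoured. Among the measured compounds shown here, the only anchor is compound 3 (76200 nM), which also differs in its amide side chain, so the range stays wide. For compound 4 the estimated value is 60000 nM (expected range 15000 nM to 200000 nM).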

Compound 4, half-maximal cytotoxic concentration: 68600 nM
Compound 4: the middle estimate sits 1.1-fold (0.06 log units) below what was measured; the range from low to high includes it.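

Within the data shown here, compound 2 has no single number in this assay, so no step from it to compound 4 can be read. Going by these compounds, whether chloro in place of nitro shifts this read-out stays open, and nothing offered here bears on the result.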